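The source may report more compounds than this note shows. Statements on the series, on what has been measured and on what is new or still open speak of the compounds shown alone.

Series notes, an ADME assay (liver) for metabolic stability, with Liver microsome (Homo sapiens) as the target, read by LC-MS, using microsomes and NADPH, tested at 1 uM; a higher number here means that the compound lasts longer, a lower number that the compound disappears faster.

Measured so far:
- compound 1, `CC(C)(C)c1cc(NC(=O)[C@@H]2CCCCN2C2CC2)no1`: 0.183 h
- compound 2, `CC(C)CN1CCCC[C@H]1C(=O)Nc1cc(C(C)(C)C)on1`: 0.1 h
- compound 3, `CC(C)(C)c1cc(NC(=O)[C@@H]2CCCCN2CC2CCOCC2)no1`: 0.183 h

For the measured compounds named here, compound 1 sits level with compound 3 at the digits given, no change at the digits printed from compound 1 to compound 3 (within the scatter), and the only other measured value, that of compound 2, differs from it by a 1.8-fold lower number from compound 1 to compound 2 (0.26 log units; within the scatter), which is within the scatter. All three numbers therefore sit in one band.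

Compound 4, `CC(C)(C)c1cc(NC(=O)[C@@H]2CCCCN2C(=O)c2ccccc2)no1`, is the next structure: benzoyl in place of cyclopropyl on an amine nitrogen in a ring. The measured steps all concern that same amine nitrogen, but each exchanges one saturated group for another: a 1.8-fold lower number from compound 1 to compound 2 (0.26 log units; within the scatter), no change at the digits printed from compound 1 to compound 3 (within the scatter) and a 1.8-fold higher number from compound 2 to compound 3 (0.26 log units; within the scatter), none beyond the scatter. Going by the values given here, no measured step introduces a benzoyl or any carbonyl at this position, so there is no direct guide for the size of the change in this assay. On this evidence the expected step is a 1.0-fold lower number from compound 1 to compound 4 (0.01 log units; within the scatter), that is, none beyond the scatter, with the range widened for the untested kind of change. Compound 4 is estimated at 0.18 h, between 0.07 h and 0.5 h.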

Compound 4, half-life: 0.683 h
Estimate against measurement, compound 4: 3.8-fold (0.58 log units) below; measured number above the stated range.
By their numbers in this assay, from the lowest: compounds 2, 1 and 3 (each within the scatter of the next); then compound 4.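

In this assay the amine nitrogen in the ring now shows steps beyond the scatter: a 3.7-fold higher number from compound 1 to compound 4 (0.57 log units; beyond the scatter) and a 3.7-fold higher number from compound 3 to compound 4 (0.57 log units; beyond the scatter) and also a 6.8-fold higher number from compound 2 to compound 4 (0.83 log units; beyond the scatter) all run in the same direction. Cyclopropyl, isobutyl and (oxan-4-yl)methyl stayed within the scatter of one another, so among the groups shown, only benzoyl separates from the others at this position. Benzoyl brings a carbonyl and a six-membered aromatic ring together, and no measurement bearing on the origin of this step is available.

As far as these compounds go, whether the carbonyl alone, as in acetyl, or the aromatic ring alone, as in benzyl, would give a similar step remains open. Also open, from the compounds shown here alone, is how a fluorine or methoxy on the aromatic ring of benzoyl would read.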